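The source may report more compounds than this note shows. Statements on the series, on what has been measured and on what is new or still open speak of the compounds shown alone.

Measured in a functional assay on Jurkat cells for inhibition of Apoptosis regulator Bcl-2 (Homo sapiens); on this read-out higher numbers stand for weaker inhibition of growth and lower numbers for stronger inhibition of growth:

Compound 1, `CCOC(=O)C1=C(N)Oc2ccc(C3CCCC3)cc2C1C(C#N)C(=O)OCC`: 3800 nM
Compound 2, `CCOC(=O)C1=C(N)Oc2ccccc2C1C(C#N)C(=O)OCC`: 94000 nM

Going by the values given here, compound 2 stands at the highest of the two numbers; its nearest neighbour is compound 1, and the single measured step between them is a 25-fold higher number from compound 1 to compound 2 (1.39 log units; beyond the scatter), seen when hydrogen replaced cyclopentyl. Compound 3, `CCOC(=O)C1=C(N)Oc2ccc(-c3ccc(C(C)(C)C)cc3)cc2C1C(C#N)C(=O)OCC`, differs from compound 2 by 4-(tert-butyl)phenyl in place of hydrogen on an aromatic carbon. That change puts a new group at the same position where compound 1 carries cyclopentyl, so the step from compound 1 to compound 2 is the one that bears on it, and a large drop in the number is expected. Compound 3 is therefore estimated at 3000 nM, with a range from 700 nM to 15000 nM, meaning an expected 31-fold lower number from compound 2 to compound 3 (1.50 log units; beyond the scatter).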

Compound 3, concentration for 50% growth inhibition: 990 nM
Compound 3: middle estimate off by 3.0-fold (0.48 log units), on the high side; measured number inside the range.
By their numbers in this assay, from the lowest: compound 3; then compound 1; then compound 2.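

Adding 4-(tert-butyl)phenyl to the unsubstituted core gives a 95-fold lower number from compound 2 to compound 3 (1.98 log units; beyond the scatter) and is the largest step seen so far. The same group also outdoes cyclopentyl at this place, with a 3.8-fold lower number from compound 1 to compound 3 (0.58 log units; beyond the scatter) so this position accepts an aromatic ring of 10 heavy atoms in all, not only a saturated ring. Nothing available explains why the number falls. Still open, going by these compounds, is whether plain phenyl, without the tert-butyl end, would keep this gain, and how a group carrying an amine or a carboxylic acid would fare here.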